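The source may report more compounds than this note shows. Statements on the series, on what has been measured and on what is new or still open speak of the compounds shown alone.

In a functional assay on SW1573 cells (Homo sapiens) for antiproliferative activity, read by sulforhodamine B assay, with a stated time of 48 h (on this read-out higher numbers stand for weaker inhibition of growth and lower numbers for stronger inhibition of growth), compound 1 `CC(C)(C)[Si](C)(C)O[C@H]1CCCO[C@@H]1COCC(=O)OCc1ccccc1` gives 17000 nM, and compound 2 `CC(C)(C)[Si](C)(C)O[C@@H]1CCCO[C@@H]1COCC(=O)OCc1ccccc1`, which differs only in configuration as drawn, gives 29000 nM. The step of a 1.7-fold higher number from compound 1 to compound 2 (0.23 log units; within the scatter) shows that these two stand level. Compound 3 `O=C(COC[C@H]1OCCC[C@@H]1O)OCc1ccccc1` brings a different kind of change, (a hydrogen atom in place of a group of 7 heavy atoms (6 carbon, 1 silicon; no ring), on an oxygen on a saturated carbon), on an oxygen on a saturated carbon. Among the measured compounds shown here, the one measured step concerns configuration alone, so it gives no direct measure for this replacement. A modest loss of growth inhibition is expected, an estimated step of a 2.4-fold higher number from compound 1 to compound 3 (0.37 log units; beyond the scatter) in this assay. For compound 3 the estimated value is 40000 nM, with an expected range of 15000 nM to 100000 nM.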

Compound 3, concentration for 50% growth inhibition: > 100000 nM
Compound 3 ended at the assay's limit; the forecaster's own chance of this, stated with the estimate: 30%; at least 2.5-fold (0.39 log units) between middle value and limit.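

In this assay, putting a hydrogen atom in place of the group of 7 heavy atoms (6 carbon, 1 silicon; no ring) on this oxygen gives an at least 5.8-fold higher number from compound 1 to compound 3 (0.76 log units; beyond the scatter). Unlike the change in configuration, this replacement at the position produces a clear loss of growth inhibition. Compound 3 gives > 100000 nM, which is a limit of the assay and not a number, so the full size of the step stays unknown: the limit of > 100000 nM in this assay, at which 1 of the 3 values shown sits.

The compounds shown leave open whether a methyl ether or a benzyl ether on this oxygen would keep the growth inhibition of compound 1. They also leave open whether the hydroxyl group behaves the same in the other configuration.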